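This account rests on a few compounds, and the source may have more. Where it says the series, first, only, none or still open, it means among the compounds named here.

Measured so far:
- compound 1 `CCCCCCCCCCc1cn(C[C@H](O)[C@H]2OC(=O)C(OCc3ccccc3)=C2OCc2ccccc2)nn1` gives > 100000 nM in an ADME assay on HFF cells (Homo sapiens) for cytotoxicity, read by MTT assay, with a stated time of 72 h; a lower number here means a stronger inhibitor, a higher number a weaker inhibitor
- compound 2 `COc1ccccc1-c1cn(C/C=C2\OC(=O)C(OCc3ccccc3)=C2OCc2ccccc2)nn1` gives > 100000 nM in this assay

For compound 1 the value in this assay is a limit of the assay, not a measured number. The value of compound 2 is likewise a limit. Compound 1 therefore stands at the limit of > 100000 nM in this assay, at which 2 of the 2 values shown sit, so nothing separates the two measured compounds on the numbers shown.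

Compound 3 `C[Si](C)(C)c1cn(C[C@H](O)[C@H]2OC(=O)C(OCc3ccccc3)=C2OCc2ccccc2)nn1` is not yet measured. It differs from compound 1 in one place: a group of 4 heavy atoms (3 carbon, 1 silicon; no ring) in place of a group of 10 heavy atoms (10 carbon; no ring), on an aromatic carbon. Among the measured compounds shown here, no measured pair in this set shows how such a change acts, so the expected step in this assay from compound 1 to compound 3 is none beyond the usual scatter, in either direction. Compound 3 is therefore estimated at 100000 nM, with a range from 40000 nM to 300000 nM, meaning an expected step of a number no higher from compound 1 to compound 3 (the limit leaves the size open), and most likely the assay again reports only a limit.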

Compound 3, half-maximal inhibitory concentration: 20000 nM
Beside the measured number, compound 3's estimate is 5.0-fold (0.70 log units) above it; the whole stated range lies above it.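

In this assay, replacing the decyl group with the group of 4 heavy atoms (3 carbon, 1 silicon) on the same aromatic carbon gives an at least 5.0-fold lower number from compound 1 to compound 3 (0.69 log units; beyond the scatter). Among the compounds shown here, this shows that the group at this position can change the number in this cell test, which the earlier compounds could not show. Compound 3 is also the only compound shown with a measured number rather than a limit, and the other two values are limits: the limit of > 100000 nM in this assay, at which 2 of the 3 values shown sit.

As far as these compounds go, the true size of the step remains open, since compound 1 has only a limit, and this single change both shortens the group and brings in silicon, so the two cannot be told apart. A tert-butyl group or a butyl chain at this position would help to show whether silicon matters or the smaller group alone is enough.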